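Dichlorophenyl ether variants of a bicyclic amino diacid

The compounds below may be only part of what the source reports. "The series", "measured", "known", "first", "only" and "open" are said of these compounds alone.

Three ethers of the shared core are in hand. Compound 1 `N[C@]1(C(=O)O)[C@H]2[C@@H](C[C@H]1OCCCc1ccccc1)[C@]2(F)C(=O)O` carries a phenethyl group and gives 9.83 nM in an assay on CHO cells for binding affinity to metabotropic glutamate receptor 2 (Rattus norvegicus); on this read-out lower numbers stand for stronger inhibition and higher numbers for weaker inhibition. Compound 2 `N[C@]1(C(=O)O)[C@H]2[C@@H](C[C@H]1OCc1ccc(Cl)cc1Cl)[C@]2(F)C(=O)O` gives 3.89 nM in this assay. Compound 3 `N[C@]1(C(=O)O)[C@H]2[C@@H](C[C@H]1OCc1cc(Cl)ccc1Cl)[C@]2(F)C(=O)O` gives 11.8 nM in this assay, the highest of the three numbers; against compound 1 the gap is a 1.2-fold higher number from compound 1 to compound 3 (0.08 log units; within the scatter), while a 3.0-fold higher number from compound 2 to compound 3 (0.48 log units; beyond the scatter) sets it apart from compound 2.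

Compound 4 `N[C@]1(C(=O)O)[C@H]2[C@@H](C[C@H]1OCc1c(Cl)cccc1Cl)[C@]2(F)C(=O)O` is the next variant: 2,6-dichlorophenyl in place of 2,5-dichlorophenyl on a saturated chain carbon bound to an oxygen on a saturated carbon. The step that bears most directly is the shift of chlorine placement between two dichlorophenyl ethers, a 3.0-fold higher number from compound 2 to compound 3 (0.48 log units; beyond the scatter), a modest but real change; a 2.5-fold lower number from compound 1 to compound 2 (0.40 log units; beyond the scatter) shows a similar size in the other direction. Moving a chlorine around the ring therefore shifts this assay by a modest amount, and no measured case tells the direction for 2,6-dichlorophenyl. A step of about a 1.0-fold higher number from compound 3 to compound 4 (0.01 log units; within the scatter) is expected, within or close to the scatter. Compound 4 is estimated at 12 nM in this assay, between 4 nM and 40 nM.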

Compound 4, inhibition constant: 4.3 nM
Estimate against measurement, compound 4: 2.8-fold (0.45 log units) above; the measured number falls inside the stated range.
By their numbers in this assay, from the lowest: compounds 2 and 4 (each within the scatter of the next); then compounds 1 and 3 (each within the scatter of the next).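

Chlorine placement matters here only for one of the three dichlorophenyl ethers in this assay: a 1.1-fold higher number from compound 2 to compound 4 (0.04 log units; within the scatter) puts 2,6-dichlorophenyl level with 2,4-dichlorophenyl, whereas a 2.7-fold lower number from compound 3 to compound 4 (0.44 log units; beyond the scatter) separates it from 2,5-dichlorophenyl. Against phenethyl, a 2.3-fold lower number from compound 1 to compound 4 (0.36 log units; beyond the scatter) runs in the same direction as a 2.5-fold lower number from compound 1 to compound 2 (0.40 log units; beyond the scatter), so two of the dichlorophenyl ethers give lower numbers than compound 1, and compound 3 goes against this with a 1.2-fold higher number from compound 1 to compound 3 (0.08 log units; within the scatter). Nothing at hand accounts for why 2,5-dichlorophenyl stands apart from the other two placements.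

Going by these compounds, whether 2,6-difluorophenyl or a single-chlorine phenyl would hold the number of compound 4 at this place remains open. So does the outcome of a longer chain carrying 2,6-dichlorophenyl, or of an amine or carboxylic acid on the phenyl ring.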